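The source may report more compounds than this note shows. Statements on the series, on what has been measured and on what is new or still open speak of the compounds shown alone.

Among the compounds with values here, compound 3 `COc1cc2ncnc(NNC(=S)NC(=O)c3ccccc3)c2cc1OC` has the lowest number of the three measured so far: in a functional assay on MGC-803 cells (Homo sapiens) for cytotoxicity, read by MTT assay, with a stated time of 72 h (a lower number here means a stronger inhibitor, a higher number a weaker inhibitor), compound 3 gives 3050 nM, whereas compound 1 `COc1cc2ncnc(NNC(=S)NC(=O)c3ccc(C(F)(F)F)cc3)c2cc1OC` gives 9280 nM and compound 2 `COc1cc2ncnc(NNC(=S)NC(=O)c3ccccc3C)c2cc1OC` gives 11100 nM. Compound 4 `COc1cc2ncnc(NNC(=S)NC(=O)c3cccc(Cl)c3)c2cc1OC` differs from compound 3 by chloro in place of hydrogen on an aromatic carbon. Within the data shown here, two measured steps bear on this change, and both run in the same direction: taking a group off the benzoyl ring lowered the number, a 3.0-fold lower number from compound 1 to compound 3 (0.48 log units; beyond the scatter) and a 3.6-fold lower number from compound 2 to compound 3 (0.56 log units; beyond the scatter). Putting a chloro group onto that ring is the reverse movement, so a modest rise in this assay is expected for compound 4, a 2.1-fold higher number from compound 3 to compound 4 (0.33 log units; beyond the scatter). Compound 4 is therefore estimated at 6500 nM, with a range from 2500 nM to 16000 nM.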

Compound 4, half-maximal inhibitory concentration: 4060 nM
Compound 4: the middle estimate sits 1.6-fold (0.20 log units) above what was measured, within the range that was stated.
By their numbers in this assay, from the lowest: compounds 3 and 4 (each within the scatter of the next); then compounds 1 and 2 (each within the scatter of the next).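

In this assay, within the data shown here, chloro on an aromatic carbon meta to a large group is the first change on this ring that stays within the scatter of the unsubstituted compound: a 1.3-fold higher number from compound 3 to compound 4 (0.12 log units; within the scatter). The 3-chlorophenyl group also separates from the two other substituted rings, with a 2.7-fold lower number from compound 2 to compound 4 (0.44 log units; beyond the scatter) and a 2.3-fold lower number from compound 1 to compound 4 (0.36 log units; beyond the scatter). No measured evidence accounts for this difference. The compounds shown leave open whether chloro elsewhere on the ring would give the same result. They also leave open how an amine or a carboxylic acid would read in this place.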